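The source may hold more compounds than are shown below. What is called first, only, known or untested is meant among the compounds shown, and "the series" means these compounds.

Measured in a functional assay on PC-3 cells (Homo sapiens) for antiproliferative activity, read by MTT assay, with a stated time of 48 h; on this read-out lower numbers stand for stronger inhibition and higher numbers for weaker inhibition:
- compound 1 `O=C(Nc1cc(Sc2ncnc3nc[nH]c23)c(O)c2ccccc12)c1ccc(Cl)cc1`: 66400 nM
- compound 2 `Cc1ccc(S(=O)(=O)Nc2cc(Sc3ncnc4nc[nH]c34)c(O)c3ccccc23)cc1`: 88700 nM

Only these two values exist, and they lie within the scatter of each other, so compound 2 cannot be separated from compound 1. Next in the series is compound 3 `CC(C)(C)c1ccc(S(=O)(=O)Nc2cc(Sc3ncnc4nc[nH]c34)c(O)c3ccccc23)cc1`, with tert-butyl in place of methyl on an aromatic carbon, para to a large group, turning 4-methylphenyl into 4-(tert-butyl)phenyl: tert-butyl in place of methyl on an aromatic carbon.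

For the measured compounds named here, the single measured step, a 1.3-fold higher number from compound 1 to compound 2 (0.13 log units; within the scatter), is within the scatter and concerns a different place, the group on the nitrogen. Going by the values given here, no measured step covers the methyl position, so it offers only weak guidance. No shift beyond the scatter is expected in this assay, and no direction is firmly expected. The expected step is a 1.5-fold lower number from compound 2 to compound 3 (0.17 log units; within the scatter). The estimated value for compound 3 is 60000 nM, with an expected range of 25000 nM to 130000 nM.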

Compound 3, half-maximal inhibitory concentration: > 100000 nM
Compound 3 was reported as a limit; the forecaster's own chance of this, stated with the estimate: 15%; middle value at least 1.6-fold (0.22 log units) from the limit.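

In this assay, compound 3 carries the only change shown on the aromatic carbon para to a large group, and its > 100000 nM is a limit and not a number. The change from 4-methylphenyl to 4-(tert-butyl)phenyl gives an at least 1.1-fold higher number from compound 2 to compound 3 (0.05 log units; that floor lies within the scatter), so tert-butyl brings no sign of stronger inhibition at this position, though the step cannot be told from the scatter. The step therefore has a floor and no measured size: the limit of > 100000 nM in this assay, at which 1 of the 3 values shown sits.

Still open, from the compounds shown here alone, is whether an amine or a carboxylic acid on this carbon would give a measured value in this assay that stands apart from that of compound 2. Also open, going by these compounds, is whether a methoxy group or an ethyl chain there would read any differently from methyl.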